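Adding a Trifluoromethyl Group to a Fluorinated Urea

This account rests on a few compounds, and the source may have more. Where it says the series, first, only, none or still open, it means among the compounds named here.

Compound 1 `CCc1ccccc1NC(=O)N[C@H](C)c1ccccc1` gives 92% in an ADME assay on the whole organism with Oryza sativa as the target, tested at 10 uM; a lower number here means a stronger effect, a higher number a weaker effect of the compound at the concentration tested.
Compound 2 `C[C@@H](NC(=O)Nc1cccc(C(F)(F)F)c1)c1ccccc1` gives 70% in this assay.
Compound 3 `C[C@@H](NC(=O)Nc1ccccc1F)c1ccccc1` gives 77% in this assay.

Three ureas built on a shared core have been measured so far. In this assay compound 3 gives 77%, the second highest of the three numbers. Its nearest neighbour is compound 2, whose value lies within the usual scatter of that of compound 3, so no order between the two can be claimed. Going by the values given here, its furthest neighbour is compound 1, and the step of a number 15 percentage points lower from compound 1 to compound 3 (beyond the scatter) is the only one-place change measured here.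

The next compound, compound 4 `C[C@@H](NC(=O)Nc1cccc(C(F)(F)F)c1F)c1ccccc1`, differs from compound 3 by trifluoromethyl in place of hydrogen on an aromatic carbon. Compound 4 thus carries both the fluoro group of compound 3 and the trifluoromethyl group found in compound 2. Among the compounds with values here, no measured step isolates the addition of a trifluoromethyl group alone. Within the data shown here, the one measured step, from compound 1 to compound 3, was modest and downward. Compound 2, which carries a trifluoromethyl group, gives 70%, a number within the scatter of compound 3. On this basis a small downward step, or none beyond the scatter, is expected for compound 4 in this assay, that is a number 11 percentage points lower from compound 3 to compound 4 (beyond the scatter). The estimate for compound 4 is therefore 66%, with a range from 50% to 82%.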

Compound 4, a percentage reported as activity, at one concentration (the size of the read-out at that concentration, not a potency): 98%
Compound 4: middle estimate off by 32 percentage points, on the low side; the whole stated range lies below it.
By their numbers in this assay, from the lowest: compounds 2 and 3 (each within the scatter of the next); then compounds 1 and 4 (each within the scatter of the next).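

Trifluoromethyl in place of hydrogen, ortho to a fluoro group, gives a number 21 percentage points higher from compound 3 to compound 4 (beyond the scatter) in this assay, and a higher number here means a weaker effect. The same holds when the two groups are added in the other order: fluoro in place of hydrogen gives a number 28 percentage points higher from compound 2 to compound 4 (beyond the scatter) at the concentration tested. So on this ring, each group goes with a weaker effect when added to a ring that already carries the other, which no earlier compound could show. Nothing in hand gives a reason for this.

Going by these compounds, it remains open whether this rise is particular to trifluoromethyl or would also follow a methyl group, a chlorine atom or a nitrile at the same place. Whether a larger group there would go with a still higher number is open too.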